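A cyclohexyl exchange on the hydroxyl-bearing carbon

The source may hold more compounds than are shown below. What is called first, only, known or untested is meant among the compounds shown, and "the series" means these compounds.

- Compound 1 `O=C(NCc1cc(Cl)ccc1-n1cnnn1)[C@@H]1C[C@@H]2C[C@@H]2N1C(=O)[C@H](O)c1cccc(Cl)c1` gives 1000 nM as measured
- Compound 2 `CC(C)(C)OC[C@@H](O)C(=O)N1[C@H](C(=O)NCc2cc(Cl)ccc2-n2cnnn2)C[C@@H]2C[C@@H]21` gives 500 nM as measured

Going by the values given here, in a functional assay on a cell-free system (plasma, Homo sapiens), with a stated time of 3 min (on this read-out lower numbers stand for stronger inhibition and higher numbers for weaker inhibition), compound 2 gives 500 nM and stands level with compound 1, since only two numbers are available and they lie within the scatter of each other.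

Compound 3 `O=C(NCc1cc(Cl)ccc1-n1cnnn1)[C@@H]1C[C@@H]2C[C@@H]2N1C(=O)[C@H](O)C1CCCCC1` has not yet been measured. It carries cyclohexyl in place of (tert-butoxy)methyl on a saturated chain carbon bound to a carbonyl carbon and an oxygen on a saturated carbon, and the count for this exchange is cyclohexyl in place of (tert-butoxy)methyl on a saturated chain carbon bound to a carbonyl carbon and an oxygen on a saturated carbon with the rest of compound 2 unchanged.

Among the compounds with values here, only one measured step bears on that carbon, where (tert-butoxy)methyl replaces 3-chlorophenyl, and it is a 2.0-fold lower number from compound 1 to compound 2 (0.30 log units; within the scatter) and no more. One pair sets no trend, but it gives no reason to expect a large move, so the next exchange is expected to stay within the scatter in this assay as well. The step estimated here is no change at the digits printed from compound 2 to compound 3 (within the scatter) and nothing beyond that is expected. Compound 3 is estimated at 500 nM with an expected range between 150 nM and 1700 nM on the same scale.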

Compound 3, half-maximal inhibitory concentration: 600 nM
Compound 3: the middle estimate sits 1.2-fold (0.08 log units) below what was measured; measured number inside the range.
By their numbers in this assay, from the lowest: compounds 2, 3 and 1 (each within the scatter of the next).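

In this assay, the exchange on a saturated chain carbon bound to a carbonyl carbon and an oxygen on a saturated carbon gives a 1.2-fold higher number from compound 2 to compound 3 (0.08 log units; within the scatter) with cyclohexyl in place of (tert-butoxy)methyl, and a 1.7-fold lower number from compound 1 to compound 3 (0.22 log units; within the scatter) with cyclohexyl in place of 3-chlorophenyl, so both new steps stay within the scatter. Going by these compounds alone, the single earlier pair could not show that a six-membered non-aromatic ring of carbon only can take the place of an open group with the same count of heavy atoms, with one hydrogen-bond acceptor fewer, and still give no step beyond the scatter. Nothing in the data offers a reason for this flat picture at the position.

From the compounds shown here alone, whether an amine, a carboxylic acid or a longer chain on this carbon would carry the number beyond the scatter remains open. Going by these compounds, all three compounds also share the rest of the molecule, so it is equally open whether these exchanges would stay as small on a different core or in another read-out.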